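Replacing a Trimethoxyphenyl Group on the Shared Core

The source may report more compounds than this note shows. Statements on the series, on what has been measured and on what is new or still open speak of the compounds shown alone.

Of the compounds shown here, two sharing one core have been measured. In a functional assay on A2780 cells (Homo sapiens) for inhibition, read by MTT assay, with a stated time of 72 h (on this read-out lower numbers stand for stronger inhibition and higher numbers for weaker inhibition), compound 1 `O=C1/C(=C\c2ccccc2)c2c(ncn2COCc2ccccc2)CCN1Cc1ccc(F)cc1` gives 24800 nM and compound 2 `COc1cc(/C=C2\C(=O)N(Cc3ccccc3)CCc3ncn(COCc4ccccc4)c32)cc(OC)c1OC` gives 8970 nM. Compound 2 therefore holds the lower of the two numbers, and its gap to compound 1 lies beyond the usual scatter.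

The next compound, compound 3 `O=C1/C(=C\c2ccc(C(F)(F)F)cc2)c2c(ncn2COCc2ccccc2)CCN1Cc1ccccc1`, departs from compound 2 at one place: 4-(trifluoromethyl)phenyl in place of 3,4,5-trimethoxyphenyl on a double-bonded chain carbon bound to a double-bonded ring carbon, with 4-(trifluoromethyl)phenyl in place of 3,4,5-trimethoxyphenyl on a double-bonded chain carbon bound to a double-bonded ring carbon.

Within the data shown here, no measured step isolates this change, so the expectation rests on thin ground. Compound 1 also lacks the 3,4,5-trimethoxyphenyl group, though it differs elsewhere too, and it stands at 24800 nM. A modest rise in the number is therefore expected in this assay. The estimated change is a 1.6-fold higher number from compound 2 to compound 3 (0.19 log units; within the scatter). Compound 3 is expected at 14000 nM, within an estimated range of 5000 nM to 40000 nM.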

Compound 3, half-maximal inhibitory concentration: 28200 nM
Compound 3: middle estimate off by 2.0-fold (0.30 log units), on the low side; measured number inside the range.
By their numbers in this assay, from the lowest: compound 2; then compounds 1 and 3 (each within the scatter of the next).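

In this assay, among these compounds, replacing 3,4,5-trimethoxyphenyl with 4-(trifluoromethyl)phenyl on a double-bonded chain carbon bound to a double-bonded ring carbon gives a 3.1-fold higher number from compound 2 to compound 3 (0.50 log units; beyond the scatter), the first reading in which this position changes alone. The number therefore responds to the group at this place, and among the two groups compared, 3,4,5-trimethoxyphenyl holds the lower number. The group that leaves carries hydrogen-bond acceptors and the group that enters carries none, but nothing available ties the step to that difference or to any other cause.

The compounds shown do not separate the loss of the methoxy groups from the gain of the trifluoromethyl group. A 4-methoxyphenyl group or a 4-aminophenyl group at this place would test how far the number depends on each.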